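A few compounds are considered here, and "the series" means these few. Any claim that something is new, unique, unknown or untested is made for them only; others in the source may bear on it.

Measured so far in a functional assay on HEK293 cells for antagonist activity at transient receptor potential cation channel subfamily V member 1 (Homo sapiens), read by FLIPR and calcium flux; on this read-out higher numbers stand for weaker inhibition and lower numbers for stronger inhibition: compound 1 `CCC(CC)N1CCN(c2nc3c(c(Nc4ccc(C(F)(F)F)cc4)n2)CCN(c2ncccc2C(F)(F)F)CC3)CC1` gives 41 nM; compound 2 `CN(c1nc2c(c(Nc3ccc(C(F)(F)F)cc3)n1)CCN(c1ncccc1C(F)(F)F)CC2)C1CCCNC1` gives 3600 nM; compound 3 `CN1CCCCC1CNc1nc2c(c(Nc3ccc(C(F)(F)F)cc3)n1)CCN(c1ncccc1C(F)(F)F)CC2` gives 1760 nM.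

Compound 3 holds the second highest of the three numbers: a 2.0-fold lower number from compound 2 to compound 3 (0.31 log units; beyond the scatter) separates it from its nearest neighbour, and a 43-fold higher number from compound 1 to compound 3 (1.63 log units; beyond the scatter) separates it from compound 1. Compound 4 `CNC1CCN(c2nc3c(c(Nc4ccc(C(F)(F)F)cc4)n2)CCN(c2ncccc2C(F)(F)F)CC3)C1` differs from compound 3 by 3-(methylamino)pyrrolidin-1-yl in place of ((1-methylpiperidin-2-yl)methyl)amino on an aromatic carbon. Going by the values given here, the steps that bear on this are an 88-fold higher number from compound 1 to compound 2 (1.94 log units; beyond the scatter) and a 43-fold higher number from compound 1 to compound 3 (1.63 log units; beyond the scatter), both large, and the modest 2.0-fold lower number from compound 2 to compound 3 (0.31 log units; beyond the scatter). Compound 4 carries its amine ring directly on the aromatic carbon, as compound 1 does, so a step down in this assay is expected, roughly a 3.5-fold lower number from compound 3 to compound 4 (0.55 log units; beyond the scatter), though not all the way back to compound 1. For compound 4 the estimate is 500 nM, with a range of 100 nM to 2500 nM.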

Compound 4, half-maximal inhibitory concentration in the transient receptor potential cation channel subfamily V member 1 assay: 2790 nM
Beside the measured number, compound 4's estimate is 5.6-fold (0.75 log units) below it; the measured number lies above the stated range.
By their numbers in the transient receptor potential cation channel subfamily V member 1 assay, from the lowest: compound 1; then compounds 3, 4 and 2 (each within the scatter of the next, the first and the last beyond it).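

In the transient receptor potential cation channel subfamily V member 1 assay compound 4, with the new group 3-(methylamino)pyrrolidin-1-yl, gives 2790 nM, with no separation from the two other amines: a 1.6-fold higher number from compound 3 to compound 4 (0.20 log units; within the scatter) and a 1.3-fold lower number from compound 2 to compound 4 (0.11 log units; within the scatter). Compound 4 joins its amine ring directly to the aromatic carbon, as compound 1 does, yet that shared feature does not bring the number to that of compound 1: a 68-fold higher number from compound 1 to compound 4 (1.83 log units; beyond the scatter). Among these four compounds, only the 4-(pentan-3-yl)piperazin-1-yl group stands apart.

In a physicochemical assay for solubility, in phosphate buffer, measured as thermodynamic solubility, at pH 2 (a higher number here means a more soluble compound, a lower number a less soluble compound), compound 3 gives > 277 ug/mL, which is a limit of the assay. In the physicochemical assay compound 4 gives > 220 ug/mL, which is also a limit of the assay. The step between these two compounds cannot be read. Open, from the compounds shown here alone, is whether a piperazine with a methyl group in place of pentan-3-yl would stay with compound 1 or join the other three.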